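Nitro in place of hydrogen on two related cores

The source may report more compounds than this note shows. Statements on the series, on what has been measured and on what is new or still open speak of the compounds shown alone.

Compound 1 `Cc1ccccc1-c1cc2ccccc2[nH]1` is the parent of one pair. In an assay on isolated protein for inhibition of Aromatase (Homo sapiens), read by fluorescence, using NADPH, with a stated time of 30 min, tested at 50 uM (a lower number here means less inhibition, a higher number more inhibition at the concentration tested (going by the name of the read-out)), compound 1 gives 27.1%. Compound 2 `Cc1ccccc1-c1cc2cc([N+](=O)[O-])ccc2[nH]1` carries the change (nitro in place of hydrogen on an aromatic carbon). In this assay compound 2 gives 71.5%. The step is a number 44.4 percentage points higher from compound 1 to compound 2 (beyond the scatter).

Compound 3 `Cn1c(-c2ccc(Cl)c(Cl)c2)cc2ccccc21` is the parent of the second pair. The difference between the core of compound 3 and the core of compound 1 is not broken down here. In this assay compound 3 gives 20%, a number that lies within the scatter of the number for compound 1 and well under the number for compound 2.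

Compound 4 `Cn1c(-c2ccc(Cl)c(Cl)c2)cc2cc([N+](=O)[O-])ccc21` is not yet measured. It differs from compound 3 by nitro in place of hydrogen on an aromatic carbon. The change is the same as that from compound 1 to compound 2, at the same kind of place on the fused ring, and it occurs twice among the four compounds. Within the data shown here, only one measured step of this kind exists, so the expectation for compound 4 rests on that single step, a number 44.4 percentage points higher from compound 1 to compound 2 (beyond the scatter), applied to the number for compound 3, with the caveat that the core differs. The step from compound 3 to compound 4 in this assay is expected to be a number 35 percentage points higher from compound 3 to compound 4 (beyond the scatter), somewhat less than the measured step; how the different core bears on the change is not known from the measured compounds. Compound 4 is therefore estimated at 55%, with a range from 35% to 75%.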

Compound 4, a percentage reported as inhibition, at one concentration (the size of the read-out at that concentration, not a potency): 34%
For compound 4 the middle estimate is 21 percentage points above the measured one; measured number outside the range, below it.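

In this assay, nitro in place of hydrogen on an aromatic carbon of the core of compound 3 gives a number 14 percentage points higher from compound 3 to compound 4 (beyond the scatter), a modest step. The direction of the change carries over from one core to the other in these two pairs, but its size does not: the same change on two cores in this assay, a number 44.4 percentage points higher (beyond the scatter) from compound 1 to compound 2 and a number 14 percentage points higher (beyond the scatter) from compound 3 to compound 4, 30.4 percentage points apart, beyond the scatter of two such steps

This does not show which feature of the cores goes with the smaller step, since the core of compound 1 and the core of compound 3 differ in more than one place, and two pairs set no rule for any third core.

Still open, as far as these compounds go, is how the nitro step behaves on a core that differs from the core of compound 1 in one place only, such as one carrying a methyl on the ring nitrogen while keeping the rest of compound 1 unchanged. Also open, from the compounds shown here alone, is whether an amine or a carboxylic acid in place of the nitro, on the same aromatic carbon of the six-membered ring, would give a step closer to the larger or to the smaller of the two seen on these cores.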